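The compounds below may be only part of what the source reports. "The series", "measured", "known", "first", "only" and "open" are said of these compounds alone.

Compound 1, whose structure is `CCCCCCCC/C=C/CCCCCCCC(=O)Nc1c(C)cccc1OC`, is the starting point. In an assay on microsomes from intestine for inhibition of acyl-CoA:cholesterol acyltransferase (Oryctolagus cuniculus) (a lower number here means a stronger inhibitor, a higher number a weaker inhibitor), compound 1 gives 20 nM. Compound 2, with the structure `CCCCCCCC/C=C/CCCCCCCC(=O)Nc1c(C)cccc1OCC`, carries the change (methyl in place of hydrogen on a saturated chain carbon bound to an oxygen on an aromatic ring), which read one bond further out is methoxy to ethoxy. In this assay compound 2 gives 15 nM, and the step of a 1.3-fold lower number from compound 1 to compound 2 (0.12 log units; within the scatter) is small enough to count as no real difference.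

Compound 3, drawn as `CCCCCCCCCCC(C)(C)C(=O)Nc1c(C)cccc1OC`, has a different core: the long chain with its double bond is replaced by a shorter, fully saturated chain carrying two methyl groups on the carbon next to the carbonyl. The difference between the two cores is not broken down here. In this assay compound 3 gives 210 nM, the highest number among the three measured compounds, so it is the weakest inhibitor of the three.

Compound 4, with the structure `CCCCCCCCCCC(C)(C)C(=O)Nc1c(C)cccc1OCC`, has not yet been measured. It is built from compound 3 by the change (methyl in place of hydrogen on a saturated chain carbon bound to an oxygen on an aromatic ring), the same change as from compound 1 to compound 2, at the same place. Because that earlier step was a 1.3-fold lower number from compound 1 to compound 2 (0.12 log units; within the scatter), the step from compound 3 to compound 4 is expected to be of similar size, estimated as a 1.3-fold lower number from compound 3 to compound 4 (0.12 log units; within the scatter). Compound 4 is therefore expected to give about 160 nM in this assay, most likely between 90 nM and 300 nM. Whether the shorter, saturated core behaves like the long unsaturated one under this change is the open question.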

Compound 4, half-maximal inhibitory concentration: 180 nM
For compound 4 the middle estimate is 1.1-fold (0.05 log units) below the measured one; low and high end bracket the measured number.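

In this assay, the step from methoxy to ethoxy on the second core gives a 1.2-fold lower number from compound 3 to compound 4 (0.07 log units; within the scatter), so here too the extra methyl makes no real difference to the read-out. Set beside the same change on the first core, the two steps agree: the same change on two cores in this assay, a 1.3-fold lower number (0.12 log units; within the scatter) from compound 1 to compound 2 and a 1.2-fold lower number (0.07 log units; within the scatter) from compound 3 to compound 4, 1.1-fold (0.06 log units) apart, within the scatter of two such steps

Within this small set, then, the change carries from one core to the other, and on both cores its result is the same: no step that can be told apart from the scatter of repeated measurements. That is agreement between two very small steps in one assay, on two cores only, so it does not show that a change with a larger step would carry across in the same way, nor that any other change would behave alike.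

The compounds shown leave open what a longer chain, such as propoxy or butoxy, or a chain ending in an amine or a carboxylic acid would do in place of the ethoxy group. They also leave open which part of the difference between the two cores, the chain length, the double bond or the two added methyl groups, goes with the gap between their values.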